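Ethoxycarbonyl on the Ureido Nitrogen: Expected Cytotoxicity

The compounds below may be only part of what the source reports. "The series", "measured", "known", "first", "only" and "open" are said of these compounds alone.

Compound 3 `Cc1cn([C@@H]2O[C@H](CO[Si](C)(C)C(C)(C)C)[C@@]3(OS(=O)(=O)C=C3NC(N)=O)[C@H]2O[Si](C)(C)C(C)(C)C)c(=O)n(C)c1=O` carries an unsubstituted ureido group on the shared core. In an ADME assay on HEL cells (Homo sapiens) for cytotoxicity, with a stated time of 3 days (on this read-out higher numbers stand for lower toxicity in this test and lower numbers for higher toxicity in this test), compound 3 gives 16000 nM, the highest of the two numbers shown, with compound 2 `Cc1cn([C@@H]2O[C@H](CO[Si](C)(C)C(C)(C)C)[C@@]3(OS(=O)(=O)C=C3NC(=O)NCc3ccccc3)[C@H]2O[Si](C)(C)C(C)(C)C)c(=O)n(C)c1=O` nearest at 4000 nM. Compound 1 `Cc1cn([C@@H]2O[C@H](CO[Si](C)(C)C(C)(C)C)[C@@]3(OS(=O)(=O)C=C3NC(=O)NC(=O)c3ccccc3)[C@H]2O[Si](C)(C)C(C)(C)C)c(=O)n(C)c1=O` carries a benzoyl on that nitrogen instead, and in this assay compound 1 gives >= 80000 nM, which is a limit of the assay rather than a number. The step of a 4.0-fold higher number from compound 2 to compound 3 (0.60 log units; beyond the scatter) is modest, whereas an at least 5.0-fold lower number from compound 1 to compound 3 (0.69 log units; beyond the scatter) and an at least 20-fold lower number from compound 1 to compound 2 (1.30 log units; beyond the scatter) show that removing the benzoyl, or replacing it by benzyl, brought the number down from the limit. Compound 4 `CCOC(=O)NC(=O)NC1=CS(=O)(=O)O[C@@]12[C@@H](CO[Si](C)(C)C(C)(C)C)O[C@@H](n1cc(C)c(=O)n(C)c1=O)[C@@H]2O[Si](C)(C)C(C)(C)C` differs from compound 3 by ethoxycarbonyl in place of hydrogen on an amide-type nitrogen. The step that bears most on this change is an at least 5.0-fold lower number from compound 1 to compound 3 (0.69 log units; beyond the scatter), read in reverse: substituting the ureido hydrogen with a carbonyl-bearing group took the number to the limit. A higher number in this assay is therefore expected for compound 4, likely large, and possibly again only a limit. Compound 4 is estimated at 50000 nM, within 16000 nM to 100000 nM. This expectation corresponds to a 3.1-fold higher number from compound 3 to compound 4 (0.49 log units; beyond the scatter).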

Compound 4, minimum cytotoxic concentration: 10000 nM
Compound 4: the middle estimate sits 5.0-fold (0.70 log units) above what was measured; the whole stated range lies above it.
By their numbers in this assay, from the lowest: compound 2; then compounds 4 and 3 (each within the scatter of the next). At a limit, above all of these: compound 1.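

In this assay, ethoxycarbonyl in place of hydrogen on the amide-type nitrogen gives a 1.6-fold lower number from compound 3 to compound 4 (0.20 log units; within the scatter), so a carbonyl on this nitrogen does not by itself go with a higher number. Ethoxycarbonyl compares with benzyl as a 2.5-fold higher number from compound 2 to compound 4 (0.40 log units; beyond the scatter), and ethoxy in place of phenyl on the carbonyl carbon gives an at least 8.0-fold lower number from compound 1 to compound 4 (0.90 log units; beyond the scatter), so among these compounds the high reading goes with benzoyl and not with the carbonyl alone. The value of compound 1 is a limit and not a number: the limit of >= 80000 nM in this assay, at which 1 of the 4 values shown sits.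

The compounds shown leave open whether a small acyl group such as acetyl on this nitrogen would read like ethoxycarbonyl or like benzoyl. They also leave open whether phenoxycarbonyl, which keeps the phenyl but adds an oxygen, would follow benzoyl.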